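Working notes: aryl substituent exchange on the compound 1 core

The source may hold more compounds than are shown below. What is called first, only, known or untested is meant among the compounds shown, and "the series" means these compounds.

Measured so far:
compound 1 `COc1cc(C2CCN(C[C@@H](C)O)CC2)ccc1Nc1ncc2ccc(-c3ccccc3N(C)S(C)(=O)=O)n2n1`: 0.183 h
compound 2 `COc1cc(C2CCNCC2)ccc1Nc1ncc2ccc(-c3ccccc3N(C)S(C)(=O)=O)n2n1`: 0.367 h

In an in vitro ADME assay on microsomes from liver (Rattus norvegicus, strain Sprague-Dawley) for metabolic stability, using NADPH, with a stated time of 10 min, tested at 0.5 uM (a lower number here means that the compound disappears faster, a higher number that the compound lasts longer), compound 1 gives 0.183 h, and compound 2 gives 0.367 h in this assay. Going by the values given here, the only measured step, a 2.0-fold higher number from compound 1 to compound 2 (0.30 log units; within the scatter), touches the amine nitrogen of the ring and not the aryl group, so the two numbers sit within the scatter of each other and compound 1 cannot be placed above or below compound 2.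

Compound 3 `COc1cc(C2CCN(C[C@@H](C)O)CC2)ccc1Nc1ncc2ccc(-c3ccccc3OC)n2n1` differs from compound 1 by methoxy in place of methyl(methylsulfonyl)amino on an aromatic carbon. Among the compounds with values here, none of the measured pairs changes this aryl group, so no step in this assay bears on the change directly; the step from compound 1 to compound 2 only shows that the series so far varies within the scatter. Within the data shown here, with no relevant step in hand, the working expectation is a number close to that of compound 1, and the estimated step of a 1.1-fold higher number from compound 1 to compound 3 (0.04 log units; within the scatter) is taken as none beyond the scatter. For compound 3 the estimate in this assay is 0.2 h, with a range from 0.08 h to 0.5 h.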

Compound 3, half-life: > 0.666 h
Compound 3: no number, only a limit (the forecaster's own chance of this, stated with the estimate: 5%); at least 3.3-fold (0.52 log units) between middle value and limit.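

In this assay, going by these compounds alone, replacing methyl(methylsulfonyl)amino with methoxy on an aromatic carbon, ortho to a large group, gives an at least 3.6-fold higher number from compound 1 to compound 3 (0.56 log units; beyond the scatter), the first step that lies beyond the scatter. The only earlier step, a 2.0-fold higher number from compound 1 to compound 2 (0.30 log units; within the scatter), changes the amine nitrogen in the ring and stays within the scatter, so among the compounds shown, this aryl position is the one where a change clearly moves the half-life. Compound 3 gives > 0.666 h, which is a limit of the assay and not a number, so the step has a lower bound but no upper one: the limit of > 0.666 h in this assay, at which 1 of the 3 values shown sits.

Going by these compounds, this single pair cannot separate the loss of methyl(methylsulfonyl)amino from the arrival of methoxy, so it remains open what a fluorine, a nitrile or a plain methylsulfonyl group on the same carbon would give. On these data alone, it also remains open whether the methoxy step carries over to the core of compound 2, where the amine nitrogen bears hydrogen in place of 2-hydroxypropyl.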